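Solubility notes: cyclohexylmethyl in place of the aryl ether

The compounds below may be only part of what the source reports. "The series", "measured", "known", "first", "only" and "open" are said of these compounds alone.

Measured in a physicochemical assay for solubility, with a stated time of 18 h, at pH 7.4; a lower number here means a less soluble compound, a higher number a more soluble compound:
compound 1 `COc1ccc(Oc2ccc3c(NCCCNCc4cc(F)ccc4OC)ccnc3c2)cc1`: 14500 nM
compound 2 `COc1ccc(Oc2ccc3c(NCCCNCc4cccc(OC)c4O)ccnc3c2)cc1`: 14500 nM
compound 3 `COc1ccc(Oc2ccc3c(NCCCNCc4ccco4)ccnc3c2)cc1`: 14500 nM

Compound 2 stands level with compound 1 and compound 3; the steps of no change at the digits printed from compound 1 to compound 2 (within the scatter), no change at the digits printed from compound 2 to compound 3 (within the scatter) and no change at the digits printed from compound 1 to compound 3 (within the scatter) all stay within the scatter. Compound 4 `COc1cccc(CNCCCNc2ccnc3cc(CC4CCCCC4)ccc23)c1O` differs from compound 2 by cyclohexylmethyl in place of 4-methoxyphenoxy on an aromatic carbon. All three measured steps change only the group on the saturated chain carbon bound to the amine nitrogen, so none of them bears on a change at this aromatic carbon, and they give no ground for a direction. The estimated step of a 2.1-fold lower number from compound 2 to compound 4 (0.32 log units; beyond the scatter) is therefore a guess that is set modestly downward with a wide range. Compound 4 is expected at 7000 nM, between 1500 nM and 25000 nM.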

Compound 4, solubility: 4200 nM
For compound 4 the middle estimate is 1.7-fold (0.22 log units) above the measured one; low and high end bracket the measured number.
By their numbers in this assay, from the lowest: compound 4; then compounds 1, 2 and 3 (each within the scatter of the next).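

In this assay, this aromatic carbon responds where the saturated chain carbon did not: cyclohexylmethyl in place of 4-methoxyphenoxy gives a 3.5-fold lower number from compound 2 to compound 4 (0.54 log units; beyond the scatter), while the three changes on the chain carbon stay within the scatter. The change replaces an aromatic ring with a non-aromatic one and also removes both hydrogen-bond acceptors of the leaving group, so the step does not separate these differences. No measurement on hand bears on the cause of this step.

Open, from the compounds shown here alone, is whether the step carries over to the furan-2-yl or 5-fluoro-2-methoxyphenyl compounds. Also open, going by these compounds, is how an amine or a carboxylic acid would read at this aromatic carbon.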